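The source may hold more compounds than are shown below. What is called first, only, known or untested is meant among the compounds shown, and "the series" means these compounds.

Among the compounds with values here, compound 3 `CC1(Nc2ccc(NC(=O)c3cc(Cl)ccc3O)c(Cl)c2)CCCCC1` carries 1-methylcyclohexyl on a nitrogen on an aromatic ring of the shared core, and in an ADME assay on A549 cells (Homo sapiens) for cytotoxicity, read by LDH release, with a stated time of 15 h (a higher number here means that more compound is tolerated, a lower number that less compound is tolerated), compound 3 gives 86500 nM, one of only two numbers obtained; the other belongs to compound 1 `O=C(Nc1ccc(NCc2ccco2)cc1Cl)c1cc(Cl)ccc1O`, and in this assay compound 1 gives 76300 nM, which sits within the scatter of compound 3. Compound 2 `O=C(Nc1ccc(NCc2ccc(F)cc2)cc1Cl)c1cc(Cl)ccc1O` was taken into this assay, and for compound 2 the entry reads "not determined" (no result reported), so no result was obtained. Within the data shown here, the single measured change on that nitrogen, a 1.1-fold higher number from compound 1 to compound 3 (0.05 log units; within the scatter), stays within the scatter.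

Compound 4 `O=C(Nc1ccc(NCc2ccccc2)cc1Cl)c1cc(Cl)ccc1O` differs from compound 3 by benzyl in place of 1-methylcyclohexyl on a nitrogen on an aromatic ring. Among the measured compounds shown here, the only step that bears on it, a 1.1-fold higher number from compound 1 to compound 3 (0.05 log units; within the scatter), replaced one group on the same nitrogen with another without moving the number beyond the scatter, so the exchange for benzyl is expected to leave this assay essentially where it stands; the expected step is a 1.1-fold lower number from compound 3 to compound 4 (0.03 log units; within the scatter), none beyond the scatter. Compound 4 is therefore estimated at 80000 nM in this assay, with a range from 40000 nM to 160000 nM.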

Compound 4, half-maximal cytotoxic concentration: 81300 nM
The estimate for compound 4 lay 1.0-fold (0.01 log units) below the measured number, within the range that was stated.
By their numbers in this assay, from the lowest: compounds 1, 4 and 3 (each within the scatter of the next).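

On the nitrogen on an aromatic ring, benzyl in place of 1-methylcyclohexyl gives a 1.1-fold lower number from compound 3 to compound 4 (0.03 log units; within the scatter) in this assay, so with the same count of heavy atoms, the aromatic and the non-aromatic six-membered carbon ring are not told apart here. A second ring exchange, phenyl in place of furan-2-yl on the saturated chain carbon bound to that nitrogen, gives a 1.1-fold higher number from compound 1 to compound 4 (0.03 log units; within the scatter) and so also stays within the scatter. Among compounds 1, 3 and 4, no exchange at this position has moved the number beyond the scatter.

As far as these compounds go, whether a basic amine or a carboxylic acid carried on a longer chain at this nitrogen would do so remains open. So does the effect of any change on the shared core away from this nitrogen. No available evidence bears on why these numbers stay together.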